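Shortening a fluorinated alcohol chain by one carbon

The source may report more compounds than this note shows. Statements on the series, on what has been measured and on what is new or still open speak of the compounds shown alone.

Compound 1 `CC(F)CCO` and compound 2 `CC(F)CCCO` share a chain carrying one fluorine atom and differ only in the length of the alcohol-bearing arm. In a physicochemical assay for lipophilicity, read by NMR (a lower number here means a more polar compound, a higher number a more lipophilic compound), compound 1 gives 0.17, and in this assay compound 2 gives 0.52. The structural change between them is hydroxy in place of hydroxymethyl on a saturated chain carbon, three bonds along the chain from a fluorine atom and it made the step of a number 0.35 log units lower from compound 2 to compound 1 (beyond the scatter). Compound 3 `OCCCC(F)(F)C(F)F` carries four fluorine atoms on its chain; in this assay compound 3 gives 0.97, the highest of the three numbers, standing beyond the scatter above both compound 2 and compound 1. The difference between the core of compound 3 and the core of compound 2 is not broken down here.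

Compound 4 `OCCC(F)(F)C(F)F` has not yet been measured in this assay. It arises from compound 3 by hydroxy in place of hydroxymethyl on a saturated chain carbon, three bonds along the chain from two fluorine atoms. For the measured compounds named here, this is the same kind of change as the one from compound 2 to compound 1, though not the same: there the place was three bonds along the chain from a fluorine atom, here it is three bonds along the chain from two fluorine atoms. Going by the values given here, the only guide is the single earlier occurrence, a number 0.35 log units lower from compound 2 to compound 1 (beyond the scatter), and the expected step is therefore of similar size and direction, estimated at a number 0.35 log units lower from compound 3 to compound 4 (beyond the scatter). Compound 4 is accordingly estimated at 0.62, with an expected range from 0.35 to 0.9, set wider than the scatter since the change has been seen only once and on a chain with fewer fluorine atoms.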

Compound 4, partition coefficient: 0.66
For compound 4 the middle estimate is 0.04 log units below the measured one, within the range that was stated.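

On the core of compound 3, at the place three bonds along the chain from two fluorine atoms, exchanging hydroxymethyl for hydroxy in this assay gives a number 0.31 log units lower from compound 3 to compound 4 (beyond the scatter) and so stands alongside the earlier case, three bonds along the chain from a fluorine atom, which gave a number 0.35 log units lower from compound 2 to compound 1 (beyond the scatter) on the core of compound 2. The change therefore carried from one core to the other in these two pairs, with the same direction and a modest step beyond the scatter each time, and neither pair goes against this. It does not show that the step would hold on any core beyond these two, and no measurement shown here accounts for the result.

The compounds shown leave open whether the step would persist if the shortening were carried further or applied to a longer chain, or on a chain with no fluorine atom at all. They also leave open whether the same exchange would read alike if an amine or a carboxylic acid stood in place of the hydroxy at the end of the chain.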